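This account rests on a few compounds, and the source may have more. Where it says the series, first, only, none or still open, it means among the compounds named here.

Of the compounds shown here, three that share one core have so far been tested in an assay for binding affinity to 17-beta-hydroxysteroid dehydrogenase type 2 (Homo sapiens), with a stated time of 20 min, tested at 1 uM; on this read-out lower numbers stand for less inhibition and higher numbers for more inhibition at the one concentration tested (going by the name of the read-out). Compound 1 `Oc1cccc2cc(-c3ccccc3)ccc12` carries only hydrogen on its outer ring, and in this assay compound 1 gives 20%. Compound 2 `OCc1ccc(-c2ccc3c(O)cccc3c2)cc1` carries a hydroxymethyl group instead, and compound 2 gives 31%. Compound 3 `O=[N+]([O-])c1ccc(-c2ccc3c(O)cccc3c2)cc1` carries a nitro group, and compound 3 gives 13%. On these numbers compound 3 stands lowest of the three: its distance to compound 1 is small, a number 7 percentage points lower from compound 1 to compound 3 (within the scatter), while its distance to compound 2 is clearer, a number 18 percentage points lower from compound 2 to compound 3 (beyond the scatter).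

Compound 4 `N#Cc1ccc(-c2ccc3c(O)cccc3c2)cc1` has not yet been measured in this assay. It differs from compound 3 in one place:

cyano in place of nitro on an aromatic carbon

Within the data shown here, no measured step exchanges a nitro group for a cyano group, so the only steps that bear on this change are the two in which the nitro group entered, one within the usual scatter from compound 1 and one of modest size from compound 2. Both leave compound 3 at the low end, and swapping one small group for another of a similar kind offers no reason to expect a large move from there. The step from compound 3 to compound 4 is therefore expected to stay within the scatter, a number 5 percentage points higher from compound 3 to compound 4 (within the scatter). Compound 4 is estimated at 18%, with a likely range from 8% to 30%.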

Compound 4, a percentage reported as inhibition, at one concentration (the size of the read-out at that concentration, not a potency): 12%
The estimate for compound 4 lay 6 percentage points above the measured number; measured number inside the range.
By their numbers in this assay, from the lowest: compounds 4, 3 and 1 (each within the scatter of the next); then compound 2.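

In this assay, putting a cyano group where compound 3 carries its nitro group, on the aromatic carbon para to a large group, gives a number 1 percentage points lower from compound 3 to compound 4 (within the scatter), so the two groups cannot be told apart at this position. The cyano group also cannot be separated from plain hydrogen, with a number 8 percentage points lower from compound 1 to compound 4 (within the scatter) as the step, while the comparison with the hydroxymethyl group gives a number 19 percentage points lower from compound 2 to compound 4 (beyond the scatter) and so shows a real difference; compound 2 now stands apart from three compounds that lie within the scatter of one another. No measurement shown here explains why compound 2 stands apart or why the nitro and cyano groups read alike.

Among these compounds, with only one compound standing apart, it remains open whether the higher reading belongs to the hydroxymethyl group alone or would also appear with an amine, a carboxylic acid or a longer chain at this position. On these data alone, each number also comes from one concentration, so how these compounds compare across a range of concentrations remains unknown.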